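A few compounds are considered here, and "the series" means these few. Any claim that something is new, unique, unknown or untested is made for them only; others in the source may bear on it.

Measured so far:
compound 1 `COc1ccccc1/C=C(\C(=O)c1ccc(Cl)cc1)S(=O)(=O)c1ccc(C)cc1`, 1000 nM
compound 2 `Cc1ccc(S(=O)(=O)/C(=C/c2ccc(C)s2)C(=O)c2ccc(Cl)cc2)cc1`, 50000 nM
compound 3 `COc1ccccc1/C=C(/SCc1ccc(C)cc1)C(=O)c1ccc(Cl)cc1`, 10000 nM

The values come from a functional assay on DU-145 cells (Homo sapiens) for inhibition, read by trypan blue exclusion, with a stated time of 96 h; a lower number here means a stronger inhibitor of growth, a higher number a weaker inhibitor of growth. Compound 1 and compound 2 differ in one place only: 5-methylthiophen-2-yl in place of 2-methoxyphenyl on a double-bonded chain carbon bound to a double-bonded chain carbon. That change made a 50-fold higher number from compound 1 to compound 2 (1.70 log units; beyond the scatter). Compound 3 stands between them in this assay; the difference between the core of compound 1 and the core of compound 3 is not broken down here.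

Compound 4 `Cc1ccc(CS/C(=C/c2ccc(C)s2)C(=O)c2ccc(Cl)cc2)cc1` is not yet measured. It relates to compound 3 as compound 2 relates to compound 1: 5-methylthiophen-2-yl in place of 2-methoxyphenyl on a double-bonded chain carbon bound to a double-bonded chain carbon, the same change at the same place. A weakening step of similar size is expected for compound 4 in this assay, a 30-fold higher number from compound 3 to compound 4 (1.48 log units; beyond the scatter), because a 50-fold higher number from compound 1 to compound 2 (1.70 log units; beyond the scatter) and because compound 3 already gives 10000 nM. Compound 4 is therefore estimated at 300000 nM, with a likely range from 50000 nM to 1000000 nM, and a real chance that only a limit is reported.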

Compound 4, concentration for 50% growth inhibition: 50000 nM
Compound 4: the middle estimate sits 6.0-fold (0.78 log units) above what was measured; the measured number falls inside the stated range.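

In this assay, 5-methylthiophen-2-yl in place of 2-methoxyphenyl again gives a higher number on the second core (a 5.0-fold higher number from compound 3 to compound 4 (0.70 log units; beyond the scatter)). For the compounds shown here, with only two cores, this shows nothing about what sets the size of the step or how it would run on a further core. The direction of the change carries from one core to the other, but its size does not: the same change on two cores in this assay, a 50-fold higher number (1.70 log units; beyond the scatter) from compound 1 to compound 2 and a 5.0-fold higher number (0.70 log units; beyond the scatter) from compound 3 to compound 4, 10-fold (1.00 log units) apart, beyond the scatter of two such steps

The compounds shown leave open how other groups behave at this place on a double-bonded chain carbon bound to a double-bonded chain carbon, such as an unsubstituted phenyl, a pyridine ring or a phenyl carrying an amine or a carboxylic acid. They also leave open whether the step would be nearer the larger or the smaller size on a third core.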